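A few compounds are considered here, and "the series" means these few. Any claim that something is new, unique, unknown or untested is made for them only; others in the source may bear on it.

Of the compounds shown here, three with a shared core have been measured in a functional assay on HeLa cells for antagonist activity at 5-hydroxytryptamine receptor 6 (Homo sapiens); a higher number here means a weaker inhibitor, a lower number a stronger inhibitor. Compound 1 `CC(C)n1nc(S(=O)(=O)c2cccc3ccccc23)c2cc(N3CCN(C)CC3)ccc21` gives 1.8 nM in this assay, the lowest number of the three and therefore the strongest inhibitor among them; its nearest neighbour is compound 3 `CN1CCN(c2cccc3c(S(=O)(=O)c4cccc5ccccc45)n[nH]c23)CC1`, which gives 17 nM, and the furthest is compound 2 `CN1CCN(c2ccc3[nH]nc(S(=O)(=O)c4ccccc4Cl)c3c2)CC1`, which gives 101 nM. Both gaps to compound 1 lie beyond the usual scatter of repeated measurements.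

Compound 4 `CCn1nc(S(=O)(=O)c2cccc3ccccc23)c2cc(N3CCN(C)CC3)ccc21` is not yet measured. It differs from compound 1 in one place: hydrogen in place of methyl on a saturated chain carbon bound to an aromatic nitrogen and a saturated chain carbon. In other words, the isopropyl group on the aromatic nitrogen of the shared core becomes an ethyl group. For the measured compounds named here, no measured pair shows this particular change, so there is no direct precedent for its size. A single carbon removed from a short side chain is a small change, and the expected step from compound 1 to compound 4 in this assay is a 1.8-fold higher number from compound 1 to compound 4 (0.25 log units; within the scatter), a modest move toward a weaker inhibitor that may well fall within the scatter. Compound 4 is therefore estimated at 3.2 nM, with a likely range from 1.2 nM to 9 nM.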

Compound 4, half-maximal inhibitory concentration: 1.7 nM
Beside the measured number, compound 4's estimate is 1.9-fold (0.27 log units) above it, within the range that was stated.
By their numbers in this assay, from the lowest: compounds 4 and 1 (each within the scatter of the next); then compound 3; then compound 2.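

In this assay, changing isopropyl to ethyl on the aromatic nitrogen of the shared core gives a 1.1-fold lower number from compound 1 to compound 4 (0.02 log units; within the scatter) and so leaves the reading unchanged within the scatter. For the compounds shown here, this is the first direct view of this position: no earlier pair differed here alone, and now one carbon can be removed from this side chain with no detectable loss of inhibition. Nothing available explains why the two side chains read alike.

The compounds shown do not reveal how much larger or different this side chain can become, which a longer chain such as butyl or a bulkier benzyl group would probe. A chain ending in an amine or a carboxylic acid would show whether the position accepts more than a plain carbon chain.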